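From a carboxymethyl arm to a pyridyl amide arm

The compounds below may be only part of what the source reports. "The series", "measured", "known", "first", "only" and "open" are said of these compounds alone.

Compound 1 `CN(CCNCc1cn(-c2ccc(F)cc2)nn1)CCNc1ccnc2cc(Cl)ccc12`: in a functional assay on NCI-H460 cells (Homo sapiens) for antiproliferative activity, read by sulforhodamine B assay, with a stated time of 72 h (a higher number here means a weaker inhibitor, a lower number a stronger inhibitor), compound 1 gives 34000 nM.
Compound 2 `CN(CCNCc1cn(CC(=O)O)nn1)CCNc1ccnc2cc(Cl)ccc12`: in this assay compound 2 reaches only a limit of the assay, > 200000 nM.

Compound 2 therefore stands at the weak end of the numbers shown, without an exact figure. For the measured compounds named here, the one measured step, an at least 5.8-fold higher number from compound 1 to compound 2 (0.76 log units; beyond the scatter), is known only as a bound because of the limit of > 200000 nM in this assay, at which 1 of the 2 values shown sits. Compound 3 `CN(CCNCc1cn(CCC(=O)Nc2ccccn2)nn1)CCNc1ccnc2cc(Cl)ccc12` is not yet measured; compared with compound 2 it carries ((pyridin-2-yl)carbamoyl)methyl in place of carboxy on a saturated chain carbon bound to an aromatic nitrogen. This removes the carboxy group of compound 2 and brings in an aromatic ring, a feature compound 1 also has in its 4-fluorophenyl group. Going by the values given here, the only guide is the step from compound 1 to compound 2, which went beyond the scatter toward weaker inhibition when an aromatic group gave way to carboxymethyl; moving away from carboxy is therefore expected to bring the number down again, though by an uncertain amount. Compound 3 is expected to give about 60000 nM, somewhere between 15000 nM and 200000 nM. This corresponds to an expected step of an at least 3.3-fold lower number from compound 2 to compound 3 (0.52 log units; beyond the scatter), with a real chance that the assay again reports only a limit.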

Compound 3, half-maximal inhibitory concentration: > 200000 nM
Compound 3: only a limit was reported (the forecaster's own chance of this, stated with the estimate: 30%); at least 3.3-fold (0.52 log units) between middle value and limit.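

In this assay compound 3 also stops at a limit of the assay, > 200000 nM. Swapping carboxy for ((pyridin-2-yl)carbamoyl)methyl therefore shows no readable gain, and the steps between compound 2 and compound 3 cannot be read, because both values sit at that limit: the limit of > 200000 nM in this assay, at which 2 of the 3 values shown sit. Set against the 4-fluorophenyl group, the 2-((pyridin-2-yl)carbamoyl)ethyl arm gives an at least 5.8-fold higher number from compound 1 to compound 3 (0.76 log units; beyond the scatter), so losing the carboxy group and gaining an aromatic ring were not enough to return to the measurable range of compound 1.

Compound 1 and compound 3 differ at once in the ring, the chain and the amide, and the compounds shown leave open which of these accounts for the gap. A 4-fluorobenzyl group on the same aromatic nitrogen, which keeps a fluorinated benzene ring, adds one carbon chain atom and has no amide, would help to separate these features.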